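A few compounds are considered here, and "the series" means these few. Any claim that something is new, unique, unknown or untested is made for them only; others in the source may bear on it.

Working notes on the series. In a functional assay on A-431 cells (Homo sapiens) for inhibition, read by MTT assay, with a stated time of 72 h (on this read-out lower numbers stand for stronger inhibition and higher numbers for weaker inhibition), compound 1 `O=[N+]([O-])c1ccc(-c2nnc(SCCCN3CCN(c4nc5ccccc5s4)CC3)o2)cc1` reads 46500 nM and compound 2 `Brc1ccc(-c2nnc(SCCCN3CCN(c4nc5ccccc5s4)CC3)o2)cc1` reads 51600 nM with the two numbers inside the scatter of each other, so compound 2 holds no rank apart from compound 1. Next comes compound 3 `CC(C)(C)Oc1ccc(-c2nnc(SCCCN3CCN(c4nc5ccccc5s4)CC3)o2)cc1` which has tert-butoxy in place of bromo on an aromatic carbon, para to a large group (tert-butoxy in place of bromo on an aromatic carbon). Among the compounds with values here, the only measured step that bears on this change is a 1.1-fold higher number from compound 1 to compound 2 (0.05 log units; within the scatter) at the same place, and it stays within the scatter. Within the data shown here, no measured compound carries tert-butoxy, so this single step gives thin support and the direction remains open. No step beyond the scatter is expected in this assay for this change. The expected step is a 1.1-fold lower number from compound 2 to compound 3 (0.06 log units; within the scatter) with a wide margin around it. For compound 3 the estimate is 45000 nM with an expected range from 20000 nM to 100000 nM in this read-out.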

Compound 3, half-maximal inhibitory concentration: 67000 nM
Compound 3: the middle estimate sits 1.5-fold (0.17 log units) below what was measured; low and high end bracket the measured number.
By their numbers in this assay, from the lowest: compounds 1, 2 and 3 (each within the scatter of the next).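

In this assay, tert-butoxy on an aromatic carbon para to a large group gives a 1.3-fold higher number from compound 2 to compound 3 (0.11 log units; within the scatter) and a 1.4-fold higher number from compound 1 to compound 3 (0.16 log units; within the scatter), so neither step leaves the scatter. A substituent of 5 heavy atoms with 1 hydrogen-bond acceptor, in place of the single bromine, therefore gives no reading that stands apart, and bromo, nitro and tert-butoxy hold no rank among themselves at this position. Nothing on hand offers an explanation for this result. As far as these compounds go, whether an amine or a carboxylic acid at this place would produce a step beyond the scatter remains open. Also open, from the compounds shown here alone, is whether a longer chain elsewhere on the shared core would move the number by more than any step seen at this position.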